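Acetylsulfanyl Replaces a Carbamate on a Saturated Ring Carbon

A few compounds are considered here, and "the series" means these few. Any claim that something is new, unique, unknown or untested is made for them only; others in the source may bear on it.

Compound 2 `COc1ccc(-c2c(C)nc3c(N4CC[C@@H](NC(=O)OCc5ccccc5)C4)cc(C)nn23)cc1OC` shares its core with compound 1 `CC(=O)N[C@@H]1CCN(c2cc(C)nn3c(-c4nccs4)c(C)nc23)C1`. In an ADME assay on microsomes from liver (Mus musculus) for metabolic stability, read by LC-MS, with NADPH named in the record, with a stated time of 60 min, tested at 1 uM, in the absence of a further agent (on this read-out lower numbers stand for a less stable compound and higher numbers for a more stable compound), compound 2 reaches only the assay limit of > 95%, not a number. In this assay compound 1 likewise stops at the limit of > 95%. For the measured compounds named here, both values rest at the limit of > 95% in this assay, at which 2 of the 2 values shown sit, so no measured step offers a scale for a change. Compound 3 `COc1ccc(-c2c(C)nc3c(N4CC[C@@H](SC(C)=O)C4)cc(C)nn23)cc1OC` differs from compound 2 in one place: acetylsulfanyl in place of (benzyloxycarbonyl)amino on a saturated ring carbon. Going by the values given here, with no comparable step in hand, a moderate drop beyond the usual scatter is expected, a number at least 25 percentage points lower from compound 2 to compound 3 (beyond the scatter). Compound 3 is therefore estimated at 70%, between 40% and 95%.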

Compound 3, percent of the compound remaining: > 95%
Compound 3 ended at the assay's limit (the forecaster's own chance of this, stated with the estimate: 30%); middle value at least 25 percentage points from the limit.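

The step from compound 2 to compound 3 cannot be read, as both values are limits and not numbers: the limit of > 95% in this assay, at which 3 of the 3 values shown sit. Going by these compounds, whether acetylsulfanyl in place of (benzyloxycarbonyl)amino changes the result in this assay at all remains open.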